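This account rests on a few compounds, and the source may have more. Where it says the series, first, only, none or still open, it means among the compounds named here.

Compound 1 `Cc1cc(C(=O)Nc2cccc(F)c2)nn1Cc1cc(Cl)ccc1OCc1ccccc1` gives 2.8 in a physicochemical assay for lipophilicity, at pH 7.4; on this read-out lower numbers stand for lower lipophilicity and higher numbers for higher lipophilicity.

Compound 2 `Cc1cc(C(=O)NCc2ccncc2)nn1Cc1cc(Cl)ccc1OCc1ccccc1` gives > 3.7 in this assay, and that value is a limit of the assay rather than a number.

Compound 3 `Cc1cc(NC(=O)OCc2ccccc2)nn1Cc1cc(Cl)ccc1OCc1ccccc1` gives 3.1 in this assay.

Compound 3 stands at the upper end of the two plain numbers, yet it lies within the usual scatter of compound 1, as the step of a number 0.30 log units higher from compound 1 to compound 3 (within the scatter) shows. The step of a number at least 0.60 log units lower from compound 2 to compound 3 (beyond the scatter) is beyond the scatter, but rests on the limit of > 3.7 in this assay, at which 1 of the 3 values shown sits, rather than on a number. The step of a number at least 0.90 log units higher from compound 1 to compound 2 (beyond the scatter) likewise runs into that limit.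

Compound 4 `Cc1cc(NC(=O)OCc2ccccn2)nn1Cc1cc(Cl)ccc1OCc1ccccc1` differs from compound 3 by pyridin-2-yl in place of phenyl on a saturated chain carbon bound to an oxygen next to a carbonyl group. Going by the values given here, none of the measured steps makes this exact change. The step of a number at least 0.90 log units higher from compound 1 to compound 2 (beyond the scatter) also brings a pyridine ring into the molecule, but it swaps an aryl group for an arylmethyl group at the same time, and the steps of a number 0.30 log units higher from compound 1 to compound 3 (within the scatter) and a number at least 0.60 log units lower from compound 2 to compound 3 (beyond the scatter) alter a different part of the core. The measured set therefore offers only indirect guidance, and a step of modest size downward is expected, a number 0.90 log units lower from compound 3 to compound 4 (beyond the scatter). Compound 4 is accordingly estimated at 2.2, with an expected range from 1.5 to 2.9.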

Compound 4, distribution coefficient: 3.1
Compound 4: middle estimate off by 0.90 log units, on the low side; measured number above the stated range.
By their numbers in this assay, from the lowest: compounds 1, 3 and 4 (each within the scatter of the next). At a limit, above all of these: compound 2.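

Going by these compounds alone, on a saturated chain carbon bound to an oxygen next to a carbonyl group, pyridin-2-yl in place of phenyl gives no change at the digits printed from compound 3 to compound 4 (within the scatter) in this assay, so at this place the swap of a ring carbon for a nitrogen, with its one hydrogen-bond acceptor, leaves the read-out unmoved, something no earlier step had tested. The step of a number 0.30 log units higher from compound 1 to compound 4 (within the scatter) also keeps compound 4 level with the amide compound 1, so a pyridine ring at this place does not separate the two on this read-out. The step of a number at least 0.60 log units lower from compound 2 to compound 4 (beyond the scatter) is the only new one beyond the scatter and shows that carrying a pyridine ring does not by itself put a compound at the top of this set, though compound 2 holds a limit and not a number: the limit of > 3.7 in this assay, at which 1 of the 4 values shown sits.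

Going by these compounds, whether the same flat result would hold for pyridin-3-yl, or for an amine or a carboxylic acid on the same chain carbon, stays open. With a single swap at this place, the compounds shown support no general pattern, and the true size of the gap to compound 2 remains unknown.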